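Working notes: the step from compound 2 to compound 3

The source may hold more compounds than are shown below. What is called first, only, known or untested is meant among the compounds shown, and "the series" means these compounds.

Within the data shown here, compound 2 `C=C(C)C(=O)N[C@@H](CO)C(=O)O` is the only compound with a number in an ADME assay on microsomes from liver (Mus musculus) for metabolic stability, with a stated time of 30 min; a lower number here means that less of the compound is left, a higher number that more of the compound is left; in it compound 2 gives 68%. Compound 1 `CC(C)(O)C(=O)N[C@@H](CO)C(=O)O` stands at "not determined" (no result reported) in this assay. Among the measured compounds shown here, no pair of measured compounds differs in a single place, so no measured step is available. Compound 3 `CN(C)C(=O)N[C@@H](CO)C(=O)O` differs from compound 2 by dimethylamino in place of 1-methylethenyl on a carbonyl carbon. With nothing measured for such a change, the step expected in this assay is a number 2 percentage points higher from compound 2 to compound 3 (within the scatter), no more than the usual scatter in either direction. Compound 3 is expected to give 70% in this assay, its range running from 45% to 90%.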

Compound 3, percent of the compound remaining: 30%
For compound 3 the middle estimate is 40 percentage points above the measured one; the whole stated range lies above it.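

On the carbonyl carbon, the group is not interchangeable in this assay: dimethylamino in place of 1-methylethenyl gives a number 38 percentage points lower from compound 2 to compound 3 (beyond the scatter). Both groups count 3 heavy atoms and no ring, so heavy-atom count alone does not separate them. Nothing available on the compounds explains the step.

From the compounds shown here alone, it remains open whether the step follows the nitrogen or the loss of the double bond outside aromatic rings. An isopropyl group or a methylamino group at this place would separate these two changes.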